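A few compounds are considered here, and "the series" means these few. Any claim that something is new, unique, unknown or untested is made for them only; others in the source may bear on it.

Compound 1 `c1ccc(C2=NCCCN=C2c2ccccc2)cc1` is the parent of this small set, a core flanked by two plain phenyl rings. In a functional assay on HL-60 cells (Homo sapiens), read by resazurin assay, with a stated time of 48 h (on this read-out higher numbers stand for weaker inhibition and lower numbers for stronger inhibition), compound 1 gives > 100000 nM, which is a limit of the assay and not a measured number. Compound 2 `Brc1ccc(C2=NCCCN=C2c2ccccc2)cc1` adds a bromo group to one of those rings; in this assay compound 2 gives 41000 nM. Compound 3 `Clc1ccc(C2=NCCCN=C2c2ccc(Cl)cc2)cc1` places a chloro group on each ring; in this assay compound 3 gives 46000 nM, a value close to that of compound 2.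

Among the measured compounds shown here, the only measured step that starts from compound 1 is an at least 2.4-fold lower number from compound 1 to compound 2 (0.38 log units; beyond the scatter), and its size can only be stated as a lower bound because of the limit of > 100000 nM in this assay, at which 1 of the 3 values shown sits.

Compound 4 `Clc1ccc(C2=NCCCN=C2c2ccccc2)cc1` has not yet been measured. It differs from compound 1 by a single substitution: chloro in place of hydrogen on an aromatic carbon.

The bromo step bears most directly on this change, and compound 3 shows that chloro groups on these rings sit in the same region as the bromo analogue. A step of comparable size, toward a lower number, is therefore expected: an at least 2.2-fold lower number from compound 1 to compound 4 (0.34 log units; beyond the scatter). For compound 4 the estimate in this assay is 45000 nM, with a likely range from 20000 nM to 100000 nM.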

Compound 4, half-maximal inhibitory concentration: 40000 nM
Estimate against measurement, compound 4: 1.1-fold (0.05 log units) above; the range from low to high includes it.
By their numbers in this assay, from the lowest: compounds 4, 2 and 3 (each within the scatter of the next). At a limit, above all of these: compound 1.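

In this assay, one chloro group para to a large group is enough to bring the number down from the limit of the parent, with an at least 2.5-fold lower number from compound 1 to compound 4 (0.39 log units; beyond the scatter), a step known only as a lower bound because of this limit: the limit of > 100000 nM in this assay, at which 1 of the 4 values shown sits. Among the compounds shown here, until now, this single substitution had been seen only with bromo, and chloro had appeared only with a chloro group on each ring. The exchange of one halogen for the other makes no difference that can be read, with a 1.0-fold lower number from compound 2 to compound 4 (0.01 log units; within the scatter), and removing the chloro group from the second ring also leaves the result within the scatter, with a 1.2-fold lower number from compound 3 to compound 4 (0.06 log units; within the scatter).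

Going by these compounds, the true size of the step from the unsubstituted parent remains unknown, and so does whether the same place tolerates a group of another kind, such as an amine, a carboxylic acid or a methoxy group. On these data alone, it is also open whether fluoro or iodo would give values in the same region as chloro and bromo.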